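Alkynyl and furyl substituents on a shared uracil-free core series

A few compounds are considered here, and "the series" means these few. Any claim that something is new, unique, unknown or untested is made for them only; others in the source may bear on it.

Measured compounds:
compound 1 `O=c1[nH]c(=O)n(CCC(CO)CO)cc1-c1ccco1`, < 10 nM in a functional assay on MCF7 cells (Homo sapiens) for antiproliferative activity, read by MTT assay, with a stated time of 72 h; a higher number here means a weaker inhibitor, a lower number a stronger inhibitor
compound 2 `CC(=O)OCC(CCn1cc(C#CC(C)(C)C)c(=O)n(C(=O)c2ccccc2)c1=O)COC(C)=O`, 67100 nM
compound 3 `O=c1[nH]c(=O)n(CCC(CO)CO)cc1C#CCc1ccccc1`, > 100000 nM

In this assay compound 3 gives only a limit, > 100000 nM, which is the limit of > 100000 nM in this assay, at which 1 of the 3 values shown sits. Compound 1 likewise stands at a limit, (the limit of < 10 nM in this assay, at which 1 of the 3 values shown sits), so no numerical gap between compound 1 and compound 3 can be stated beyond their lying at opposite ends of the measured window. Compound 2 sits between them with a number.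

Compound 4 `CC(C)(C)C#Cc1cn(CCC(CO)CO)c(=O)[nH]c1=O` differs from compound 3 by tert-butyl in place of benzyl on a triple-bonded carbon. Among the measured compounds shown here, no measured pair isolates this change; the only tert-butyl alkyne measured, compound 2, carries additional acyl groups, so its value is an imperfect guide. A move toward stronger inhibition from compound 3 to compound 4 is expected, an at least 6.6-fold lower number from compound 3 to compound 4 (0.82 log units; beyond the scatter), but with wide uncertainty. Compound 4 is estimated at 15000 nM, within 1500 nM to 100000 nM.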

Compound 4, half-maximal inhibitory concentration: 95900 nM
The estimate for compound 4 lay 6.4-fold (0.81 log units) below the measured number; measured number inside the range.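

In this assay, tert-butyl in place of benzyl on a triple-bonded carbon gives an at least 1.0-fold lower number from compound 3 to compound 4 (0.01 log units; that floor lies within the scatter), and this step is only a floor since compound 3 stands at a limit: the limit of > 100000 nM in this assay, at which 1 of the 4 values shown sits. Replacing furan-2-yl with 3,3-dimethylbut-1-yn-1-yl gives an at least 9500-fold higher number from compound 1 to compound 4 (3.98 log units; beyond the scatter), a large step that is also a floor since compound 1 stands at a limit: the limit of < 10 nM in this assay, at which 1 of the 4 values shown sits. Swapping benzyl for tert-butyl thus leaves this alkyne series at the weak end, and furan-2-yl remains the only group shown with strong inhibition.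

As far as these compounds go, whether a thiophene in place of furan-2-yl, or an amine or carboxylic acid at the alkyne end, would retain strong inhibition remains open.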